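The source may report more compounds than this note shows. Statements on the series, on what has been measured and on what is new or still open speak of the compounds shown alone.

Three measured compounds share one core and differ only in what hangs from the carbonyl that is bound to the amide-type nitrogen. Compound 1 `COc1cc(-c2nn(-c3cccc(NC(=O)Nc4ccc(Cl)c(Cl)c4)c3)cc2-c2ccncc2)ccc1Cl` gives 965 nM in a functional assay on SF-539 cells (Homo sapiens) for inhibition, read by sulforhodamine B assay, with a stated time of 48 h (a lower number here means a stronger inhibitor of growth, a higher number a weaker inhibitor of growth), and compound 2 `COc1cc(-c2nn(-c3cccc(NC(=O)Nc4cccc(C(F)(F)F)c4)c3)cc2-c2ccncc2)ccc1Cl` gives 890 nM in this assay; these two sit within the scatter of each other, as shown by a 1.1-fold lower number from compound 1 to compound 2 (0.04 log units; within the scatter). Compound 3 `COc1cc(-c2nn(-c3cccc(NC(=O)c4ccc(Cl)c(C(F)(F)F)c4)c3)cc2-c2ccncc2)ccc1Cl` gives 4130 nM in this assay and therefore stands with the highest of the three numbers, set apart from both companions by a 4.3-fold higher number from compound 1 to compound 3 (0.63 log units; beyond the scatter) and by a 4.6-fold higher number from compound 2 to compound 3 (0.67 log units; beyond the scatter), each beyond the scatter and each of modest size.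

Compound 4 `COc1cc(-c2nn(-c3cccc(NC(=O)Nc4ccc(Cl)c(C(F)(F)F)c4)c3)cc2-c2ccncc2)ccc1Cl` arises from compound 3 through ((4-chloro-3-(trifluoromethyl)phenyl)amino in place of 4-chloro-3-(trifluoromethyl)phenyl on a carbonyl carbon). This is the mirror image of the changes that produced the two steps into compound 3: in both of those, the loss of the amino link between carbonyl and aryl ring was accompanied by a rise in the number, and here that link is restored. On that basis a modest fall in the number is expected in this assay, of roughly the size seen in the two measured steps, which is what a 4.3-fold lower number from compound 3 to compound 4 (0.64 log units; beyond the scatter) expresses. Compound 4 is accordingly estimated at 950 nM, with a likely range from 400 nM to 2200 nM.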

Compound 4, concentration for 50% growth inhibition: 1650 nM
Beside the measured number, compound 4's estimate is 1.7-fold (0.24 log units) below it; the range from low to high includes it.
By their numbers in this assay, from the lowest: compounds 2, 1 and 4 (each within the scatter of the next); then compound 3.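

Among these compounds, with the 4-chloro-3-(trifluoromethyl)phenyl ring held constant, this assay gives the first reading of the amino link on the carbonyl carbon alone, a 2.5-fold lower number from compound 3 to compound 4 (0.40 log units; beyond the scatter), whereas both earlier steps into compound 3 changed the ring substituents along with the link. Among the three compounds that carry this link, the ring changes stay small: chloro in place of hydrogen on an aromatic carbon gives a 1.9-fold higher number from compound 2 to compound 4 (0.27 log units; within the scatter), and trifluoromethyl in place of chloro on an aromatic carbon gives a 1.7-fold higher number from compound 1 to compound 4 (0.23 log units; within the scatter), so neither step separates the compounds. No measurement at hand bears on why restoring the link lowers the number.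

What the compounds leave open is whether the effect needs the amide hydrogen of the amino link or only the added atom in that place, a question that a methylamino or a methylene link on the same carbonyl carbon would address. On these data alone, it also remains open whether the same step would appear with an unsubstituted phenyl or a pyridine ring in place of the 4-chloro-3-(trifluoromethyl)phenyl ring.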